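Ring Substituent Swap on a Shared Core: Hydrogen to Cyano

A few compounds are considered here, and "the series" means these few. Any claim that something is new, unique, unknown or untested is made for them only; others in the source may bear on it.

Compound 1 `Cc1ccc2cnc(-c3ccccc3)nc2n1` is the reference point here. In a functional assay on CHO cells for antagonist activity at metabotropic glutamate receptor 5 (Rattus norvegicus), read by FLIPR and calcium flux (a lower number here means a stronger inhibitor, a higher number a weaker inhibitor), compound 1 gives 2700 nM; this is the only plain number shown. Compound 2 `COc1ccccc1-c1ncc2ccc(C)nc2n1` carries a methoxy in place of hydrogen on an aromatic carbon. In this assay compound 2 gives > 30000 nM, which is a limit of the assay rather than a number. The step of an at least 11-fold higher number from compound 1 to compound 2 (1.04 log units; beyond the scatter) therefore shows a large loss, read against (the limit of > 30000 nM in this assay, at which 1 of the 2 values shown sits). Compound 3 `Cc1ccc2cnc(-c3cccc(C#N)c3)nc2n1` differs from compound 1 by cyano in place of hydrogen on an aromatic carbon. Among the compounds with values here, the only measured step involves a different group, so it bears on this change weakly; a cyano is small and the measured data give no direct guide. Compound 3 is expected to show a 1.4-fold lower number from compound 1 to compound 3 (0.13 log units; within the scatter), with its this assay value estimated at 2000 nM, likely between 500 nM and 8000 nM.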

Compound 3, half-maximal inhibitory concentration: 240 nM
For compound 3 the middle estimate is 8.3-fold (0.92 log units) above the measured one; measured number below the stated range.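

Compound 3 shows that the aromatic ring carrying no other substituent in compound 1 can take a new group and gain from it: the swap of hydrogen for cyano gives an 11-fold lower number from compound 1 to compound 3 (1.05 log units; beyond the scatter) in this assay. The earlier compounds shown here showed only a loss from a substituent on this ring, with the methoxy giving an at least 11-fold higher number from compound 1 to compound 2 (1.04 log units; beyond the scatter), so adding a group there does not by itself weaken the compound. Nothing measured here accounts for the gain.

On these data alone, whether the gain belongs to the cyano itself or to the carbon it sits on stays open, and so does whether a cyano on another carbon of the ring would keep it. Also open, as far as these compounds go, is how a fluorine, an amine or a carboxylic acid would behave on the same carbon.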